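The source may hold more compounds than are shown below. What is called first, only, known or untested is meant among the compounds shown, and "the series" means these compounds.

Measured in a functional assay on HCC827 cells (Homo sapiens) for cytotoxicity, read by MTT assay, with a stated time of 72 h; on this read-out lower numbers stand for stronger inhibition and higher numbers for weaker inhibition:
- compound 1 `OCCNc1ccc(Nc2ncc3nc(Nc4ccccc4)n(C4CCCC4)c3n2)cc1`: 2.8 nM
- compound 2 `c1ccc(Nc2ncc3nc(Nc4ccccc4)n(C4CCCC4)c3n2)cc1`: 2.7 nM

Among the compounds with values here, compound 2 stands within the scatter of compound 1, the only other compound measured. Compound 3 `CC(=O)Nc1ccc(Nc2ncc3nc(Nc4ccccc4)n(C4CCCC4)c3n2)cc1` follows from compound 2 by acetamido in place of hydrogen on an aromatic carbon, with acetamido in place of hydrogen on an aromatic carbon, para to a large group. Within the data shown here, the one measured step that bears on this also exchanges hydrogen for a substituent on an aromatic carbon, and it is small: a 1.0-fold lower number from compound 1 to compound 2 (0.02 log units; within the scatter). In this assay, the expected change is therefore none beyond the scatter: a 1.3-fold higher number from compound 2 to compound 3 (0.11 log units; within the scatter). Compound 3 is estimated at 3.5 nM, with an expected range of 1.2 nM to 12 nM.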

Compound 3, half-maximal inhibitory concentration: 0.47 nM
Estimate against measurement, compound 3: 7.4-fold (0.87 log units) above; measured number outside the range, below it.
By their numbers in this assay, from the lowest: compound 3; then compounds 2 and 1 (each within the scatter of the next).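

In this assay, the position para to a large group responds to substitution after all: acetamido in place of hydrogen gives a 5.7-fold lower number from compound 2 to compound 3 (0.76 log units; beyond the scatter), whereas compound 1 and compound 2 stand within the scatter of each other. With the nitrogen kept, acetyl in place of 2-hydroxyethyl gives a 6.0-fold lower number from compound 1 to compound 3 (0.78 log units; beyond the scatter), so among these three compounds a nitrogen at this position does not alone go with the lower number. No available measurement explains this difference.

From the compounds shown here alone, whether the amide hydrogen or the carbonyl matters remains open, as does whether a urea, a methanesulfonamide or a longer acyl chain here would match compound 3.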